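The source may report more compounds than this note shows. Statements on the series, on what has been measured and on what is new or still open speak of the compounds shown alone.

Measured in a functional assay on A-375 cells (Homo sapiens) for cytotoxicity, read by MTT assay, with a stated time of 72 h; a higher number here means a weaker inhibitor, a lower number a stronger inhibitor:
- compound 1 `O=C1c2c[n+]([O-])c3ccccc3c2C(=O)c2c1c1ccccc1n2Cc1cn([C@H]2O[C@H](CO)[C@@H](O)[C@H]2O)nn1`: 340 nM
- compound 2 `O=C1c2c[n+]([O-])c3ccccc3c2C(=O)c2c1c1ccccc1n2CCN1CCCC1`: 430 nM
- compound 3 `CN(C)CCCCn1c2c(c3ccccc31)C(=O)c1c[n+]([O-])c3ccccc3c1C2=O`: 470 nM

All three values lie within the scatter of one another, so compound 3 does not separate from the other two. Compound 4 `O=C1c2c[n+]([O-])c3ccccc3c2C(=O)c2c1c1ccccc1n2Cc1cn(C[C@@H](O)CO)nn1` is not yet measured. It differs from compound 3 as follows: 1-(2,3-dihydroxypropyl)-1H-1,2,3-triazol-4-yl in place of 3-(dimethylamino)propyl on a saturated chain carbon bound to an aromatic nitrogen. In words, 1-(2,3-dihydroxypropyl)-1H-1,2,3-triazol-4-yl stands in place of 3-(dimethylamino)propyl on a saturated chain carbon bound to an aromatic nitrogen.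

For the measured compounds named here, the only measured step is a 1.1-fold higher number from compound 2 to compound 3 (0.04 log units; within the scatter). It concerns a different exchange and gives only weak guidance here. Compound 1 is the closer comparison, since it also carries a 1H-1,2,3-triazol-4-yl group on that chain carbon. Compound 1 gives 340 nM, within the scatter of compound 3. From the compounds shown here alone, no step beyond the scatter is therefore expected in this assay, and the direction stays open. The estimated change is a 1.2-fold lower number from compound 3 to compound 4 (0.07 log units; within the scatter). For compound 4 the expected value is 400 nM, with an estimated range of 190 nM to 850 nM.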

Compound 4, half-maximal inhibitory concentration: 140 nM
Estimate against measurement, compound 4: 2.9-fold (0.46 log units) above; the measured number lies below the stated range.
By their numbers in this assay, from the lowest: compound 4; then compounds 1, 2 and 3 (each within the scatter of the next).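

In this assay the 1-(2,3-dihydroxypropyl)-1H-1,2,3-triazol-4-yl group, on a saturated chain carbon bound to an aromatic nitrogen, gives the first differences beyond the scatter in this set: a 3.4-fold lower number from compound 3 to compound 4 (0.53 log units; beyond the scatter) against 3-(dimethylamino)propyl, and a 3.1-fold lower number from compound 2 to compound 4 (0.49 log units; beyond the scatter) against (pyrrolidin-1-yl)methyl. The triazole alone does not account for this, since compound 1 carries it too and stays within the scatter of compound 2 and compound 3. What sits on the triazole nitrogen therefore matters, with 2,3-dihydroxypropyl in place of 3,4-dihydroxy-5-(hydroxymethyl)oxolan-2-yl giving a 2.4-fold lower number from compound 1 to compound 4 (0.39 log units; beyond the scatter) in this assay.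

No measurement in hand explains the difference. From the compounds shown here alone, it remains open whether both hydroxyl groups are needed, which a 2-hydroxyethyl or plain propyl chain on the triazole nitrogen would test.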